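A few compounds are considered here, and "the series" means these few. Any claim that something is new, unique, unknown or untested is made for them only; others in the source may bear on it.

Working notes on the series. In an ADME assay on a cell-free system (plasma, Mus musculus, strain CD1) for protein binding, read by LC-MS, using equilibrium dialysis, with a stated time of 6 h, tested at 10 uM, compound 1 (`CN1Cc2cc(-c3ccc(-c4cncc(NS(=O)(=O)c5ccc(F)cc5F)c4)s3)cnc2C1=O`) gives 99.9%. Compound 2 (`COc1ncc(-c2ccc(-c3cnc4c(c3)CN(C)C4=O)s2)cc1NS(=O)(=O)c1ccccc1[N+](=O)[O-]`) gives 99.9% in this assay, which leaves it level with compound 1 at the digits available, so the two values cannot be told apart.

The next structure is compound 3 (`COc1ncc(-c2ccc(-c3cnc4c(c3)CN(C)C4=O)s2)cc1NS(=O)(=O)c1ccc(F)cc1F`), with 2,4-difluorophenyl in place of 2-nitrophenyl on a sulfonyl sulfur.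

Within the data shown here, no measured pair shows this change or any other single change, so its size cannot be read from data. Among the measured compounds shown here, the only guide is that compound 1 at 99.9% and compound 2 at 99.9% sit at the same level. The expected a 2.0-fold higher unbound fraction from compound 2 to compound 3 (0.30 log units; within the scatter) is therefore no step beyond the scatter, with no direction favoured. For compound 3 the estimated value in this assay is 99.8%, with an expected range of 99.2% to 99.95%.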

Compound 3, plasma protein binding: 99.9%
For compound 3 the middle estimate is 2.0-fold (0.30 log units) (unbound fraction) above the measured one; the measured number falls inside the stated range.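

Among these compounds, the first single-place steps show that in this assay 2,4-difluorophenyl in place of 2-nitrophenyl on a sulfonyl sulfur gives no change at the digits printed from compound 2 to compound 3 (within the scatter), so this exchange on the sulfonyl sulfur leaves the printed read-out as it stood. Methoxy in place of hydrogen on an aromatic carbon gives no change at the digits printed from compound 1 to compound 3 (within the scatter), so this second place shows the same result with 2,4-difluorophenyl held constant. No supporting data bear on why either exchange leaves the plasma protein binding where it is.

Open, on these data alone, is whether a group of another kind on the sulfonyl sulfur, such as an aliphatic amine or a carboxylic acid, would bring the binding away from this level. Also open, as far as these compounds go, is whether a longer chain such as ethoxy or a hydroxyl group in place of methoxy would do so.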